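Trifluoromethyl in place of nitro: working notes

A few compounds are considered here, and "the series" means these few. Any claim that something is new, unique, unknown or untested is made for them only; others in the source may bear on it.

In a functional assay on NUGC-3 cells (Homo sapiens) for inhibition (a lower number here means a stronger inhibitor of growth, a higher number a weaker inhibitor of growth), compound 1 `Cc1cc(C)c2sc(NC(=O)c3ccc(C#N)cc3)nc2c1` gives 290 nM and compound 2 `Cc1cc(C)c2sc(NC(=O)c3ccc([N+](=O)[O-])cc3)nc2c1` gives 290 nM, so compound 2 stands level with compound 1. Compound 3 `Cc1cc(C)c2sc(NC(=O)c3ccc(C(F)(F)F)cc3)nc2c1` follows from compound 2 by one change: trifluoromethyl in place of nitro on an aromatic carbon. Trifluoromethyl replaces nitro on an aromatic carbon, para to a large group. Within the data shown here, one measured step bears on this place: no change at the digits printed from compound 1 to compound 2 (within the scatter), nitro in place of cyano, within the scatter. On that single step, no shift beyond the scatter is expected in this assay. The expected step is no change at the digits printed from compound 2 to compound 3 (within the scatter). For compound 3 the estimated value is 290 nM, with an estimated range of 110 nM to 750 nM.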

Compound 3, concentration for 50% growth inhibition: 290 nM
For compound 3 middle estimate and measured number coincide at the digits printed; low and high end bracket the measured number.
By their numbers in this assay, from the lowest: compounds 1, 2 and 3 (each within the scatter of the next).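

In this assay trifluoromethyl gives no change at the digits printed from compound 2 to compound 3 (within the scatter) and no change at the digits printed from compound 1 to compound 3 (within the scatter) at this place, so three groups on this aromatic carbon, para to a large group, now read level. Nitro carries hydrogen-bond acceptors and trifluoromethyl carries none, yet the value holds, so within these compounds those acceptors are not required at this place. Still open, as far as these compounds go, is whether an amine, a carboxylic acid or a longer chain at this place would also leave the value level. No supporting data bear on why these values stay level.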